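Shortening the carbamate chain on a shared core

The compounds below may be only part of what the source reports. "The series", "measured", "known", "first", "only" and "open" are said of these compounds alone.

Compound 3 `CCCCCOC(=O)N1CCN(C(=O)c2nc(Nc3cc(C4CC4)[nH]n3)c3cc(Cl)ccc3n2)C[C@H]1C` gives 12.6% in an assay for inhibition of serine/threonine-protein kinase PAK 4 (Homo sapiens), read by FRET and Z'-LYTE, with a stated time of 60 min, tested at 5 uM, in the presence of a further agent that is not named here (a lower number here means a weaker effect, a higher number a stronger effect of the compound at the concentration tested), the lowest of the three measured numbers. Compound 1 `CC(C)COC(=O)N1CCN(C(=O)c2nc(Nc3cc(C4CC4)[nH]n3)c3cc(Cl)ccc3n2)C[C@H]1C` gives 30.7% and compound 2 `CC(OC(=O)N1CCN(C(=O)c2nc(Nc3cc(C4CC4)[nH]n3)c3cc(Cl)ccc3n2)C[C@H]1C)OC(=O)C(C)(C)C` gives 23.6%. The steps of a number 18.1 percentage points lower from compound 1 to compound 3 (beyond the scatter) and a number 11 percentage points lower from compound 2 to compound 3 (beyond the scatter) both run downward toward compound 3, whereas a number 7.1 percentage points lower from compound 1 to compound 2 (within the scatter) lies within the scatter. Compound 4 `COC(=O)N1CCN(C(=O)c2nc(Nc3cc(C4CC4)[nH]n3)c3cc(Cl)ccc3n2)C[C@H]1C` differs from compound 3 by hydrogen in place of butyl on a saturated chain carbon bound to an oxygen next to a carbonyl group. The two steps that end at compound 3 bear on this change: each introduced butyl or pentyl on an oxygen next to a carbonyl group and lowered the number modestly, so taking the butyl away is expected to move the number back up by a modest amount. Compound 4 is therefore estimated at 30%, between 14% and 48%, corresponding to an expected step of a number 17.4 percentage points higher from compound 3 to compound 4 (beyond the scatter).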

Compound 4, a percentage reported as inhibition, at one concentration (the size of the read-out at that concentration, not a potency): 89.6%
The estimate for compound 4 lay 59.6 percentage points below the measured number; the measured number lies above the stated range.
By their numbers in this assay, from the lowest: compound 3; then compounds 2 and 1 (each within the scatter of the next); then compound 4.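

The earlier compounds shown here all gave low numbers and did not show how much this position can matter in this assay: with methyl on the oxygen next to a carbonyl group, the steps are a number 77 percentage points higher from compound 3 to compound 4 (beyond the scatter), a number 66 percentage points higher from compound 2 to compound 4 (beyond the scatter) and a number 58.9 percentage points higher from compound 1 to compound 4 (beyond the scatter). The pentyl, isobutyl and 1-(((tert-butyl)carbonyl)oxy)ethyl compounds differ among themselves far less than any of them differs from compound 4. Nothing available here explains this rise. The compounds shown leave open whether ethyl or propyl on that oxygen would keep the high number or fall with the longer chains.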